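The source may report more compounds than this note shows. Statements on the series, on what has been measured and on what is new or still open speak of the compounds shown alone.

Measured in a functional assay on HeLa cells (Homo sapiens) for inhibition, read by MTT assay, with a stated time of 72 h; a lower number here means a stronger inhibitor, a higher number a weaker inhibitor:
- Compound 1 `COc1cc(OC)c(OC)cc1/C=C/C(=O)c1ccc(Cl)cc1`: 36500 nM.
- Compound 2 `COc1cc(OC)c(OC)cc1/C=C/C(=O)c1ccc(-c2c[nH]cn2)cc1`: > 150000 nM, a limit.
- Compound 3 `COc1cc(OC)c(-c2cc(=O)c3cc(Cl)ccc3o2)cc1OC`: > 150000 nM, a limit.

Among the compounds with values here, compound 1 holds the only true number in the set, 36500 nM. The other two entries give no number, only (the limit of > 150000 nM in this assay, at which 2 of the 3 values shown sit).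

Next is compound 4 `COc1cc(OC)c(OC)cc1/C=C/C(=O)c1ccc(O)cc1O`, still unmeasured. It keeps the core of compound 1 and has 2,4-dihydroxyphenyl in place of 4-chlorophenyl on a carbonyl carbon.

Within the data shown here, only one measured step bears on this change: an at least 4.1-fold higher number from compound 1 to compound 2 (0.61 log units; beyond the scatter). That step also removes the chloro, and it lies beyond the scatter, although its far end is a limit and its true size is open. Among the measured compounds shown here, compound 3 provides no step from compound 1. For the measured compounds named here, a single step is thin support, and the group entering compound 4 differs from the one entering compound 2.

Going by an at least 4.1-fold higher number from compound 1 to compound 2 (0.61 log units; beyond the scatter), a modest move towards a weaker number is expected, with the estimate being a 1.6-fold higher number from compound 1 to compound 4 (0.22 log units; within the scatter). The result could still reach the limit of the assay.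

For compound 4 the estimated value is 60000 nM, with an expected range of 20000 nM to 150000 nM.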

Compound 4, half-maximal inhibitory concentration: 37600 nM
For compound 4 the middle estimate is 1.6-fold (0.20 log units) above the measured one; measured number inside the range.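

In this assay, the step to the new group is a 1.0-fold higher number from compound 1 to compound 4 (0.01 log units; within the scatter) and so shows that this carbonyl carbon can carry a ring without chloro and with hydrogen-bond donors and acceptors, while the number stays level with that of compound 1. The earlier reading of this place rested only on an at least 4.1-fold higher number from compound 1 to compound 2 (0.61 log units; beyond the scatter) and, with that step ending in a limit, could have suggested that losing the chloro was enough to lose the effect. Compound 4 rules that out as a general reading, since the chloro can go without any shift beyond the scatter, so what compound 2 shows belongs to its 1H-imidazol-4-yl group and not to the removal of chloro alone.

Still open is whether both hydroxyl groups of compound 4 are needed, and how an amine or a carboxylic acid on the same ring would read, given that no compound shown has a number clearly stronger than compound 1. Compound 2 and compound 3 stay without a true number, so neither can be ranked against compound 4, and steps that end in such values cannot be fully read: the limit of > 150000 nM in this assay, at which 2 of the 4 values shown sit.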